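Side-chain changes and cytotoxicity across the shared core

This account rests on a few compounds, and the source may have more. Where it says the series, first, only, none or still open, it means among the compounds named here.

Measured so far:
Compound 1 `O=C1O[C@@H](CO)CN1c1ccc(-n2cc(-c3ccccn3)cn2)c(F)c1` gives 59 ug/mL in an ADME assay on L02 cells (Homo sapiens) for cytotoxicity, read by MTT assay, with a stated time of 48 h; on this read-out lower numbers stand for stronger inhibition and higher numbers for weaker inhibition.
Compound 2 `O=C1CSC(=O)N1C[C@H]1CN(c2ccc(-n3cc(-c4ccccn4)cn3)c(F)c2)C(=O)O1` gives > 400 ug/mL in this assay, a limit of the assay.
Compound 3 `CC(=O)OC[C@H]1CN(c2ccc(-n3cc(-c4ccccn4)cn3)c(F)c2)C(=O)O1` gives > 400 ug/mL in this assay, likewise a limit.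

Among the compounds with values here, compound 3 therefore stands only at a limit; with compound 2 it sits at the limit of > 400 ug/mL in this assay, at which 2 of the 3 values shown sit, and the step of an at least 6.7-fold higher number from compound 1 to compound 3 (0.83 log units; beyond the scatter) is the one readable change leading to it, while a step that the two limits leave unreadable from compound 2 to compound 3. Compound 4 `CCC(=O)NC[C@H]1CN(c2ccc(-n3cc(-c4ccccn4)cn3)c(F)c2)C(=O)O1` differs from compound 3 by propanoylamino in place of acetoxy on a saturated chain carbon bound to a saturated ring carbon. Within the data shown here, no measured step in this assay covers an amide at this place, so the expectation rests on the shared limit of compounds 2 and 3. Compound 4 is expected near 400 ug/mL, within 150 ug/mL to 800 ug/mL, which means an estimated step of a number no higher from compound 3 to compound 4 (the limit leaves the size open), likely again only a limit.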

Compound 4, half-maximal inhibitory concentration: 204 ug/mL
Beside the measured number, compound 4's estimate is 2.0-fold (0.29 log units) above it, within the range that was stated.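

In this assay, propanoylamino gives a side chain that reads as a number rather than a limit, with an at least 1.9-fold lower number from compound 3 to compound 4 (0.29 log units; that floor lies within the scatter) and an at least 1.9-fold lower number from compound 2 to compound 4 (0.29 log units; that floor lies within the scatter), though both floors lie within the scatter. The step from the hydroxy group can now be sized, at a 3.5-fold higher number from compound 1 to compound 4 (0.54 log units; beyond the scatter), beyond the scatter. Compounds 2 and 3 remain limits, not numbers: the limit of > 400 ug/mL in this assay, at which 2 of the 4 values shown sit.

Going by these compounds, how a free amine or a longer acyl chain at this place would read remains open. Also open, on these data alone, is whether the amide hydrogen or the chain length governs the step from hydroxy.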